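A Methyl-Free Imidazole on the Shared Core

A few compounds are considered here, and "the series" means these few. Any claim that something is new, unique, unknown or untested is made for them only; others in the source may bear on it.

compound 1 `Cc1ccc(-c2nccn2C)cc1NC(=O)c1ccc(OCc2ccccn2)cc1` 2.8
compound 2 `Cc1ccc(-c2cnc(C)n2C)cc1NC(=O)c1ccc(OCc2ccccn2)cc1` 2.8

In a physicochemical assay for lipophilicity (on this read-out higher numbers stand for higher lipophilicity and lower numbers for lower lipophilicity), compound 1 gives 2.8 and compound 2 gives 2.8; the step of no change at the digits printed from compound 1 to compound 2 (within the scatter) lies within the scatter, so compound 2 stands level with compound 1. Compound 3 `Cc1ccc(-c2c[nH]cn2)cc1NC(=O)c1ccc(OCc2ccccn2)cc1` carries 1H-imidazol-4-yl in place of 1,2-dimethyl-1H-imidazol-5-yl on an aromatic carbon. Within the data shown here, only the one measured step bears on it, and that step was flat; no measured step covers the loss of the methyl groups together with the arrival of a hydrogen-bond donor. Compound 3 is nonetheless expected to move somewhat downward, by a number 0.50 log units lower from compound 2 to compound 3 (beyond the scatter). Compound 3 is therefore estimated at 2.3 in this assay, within 1.8 to 2.8.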

Compound 3, distribution coefficient: 2.8
Compound 3: middle estimate off by 0.50 log units, on the low side; low and high end bracket the measured number.
By their numbers in this assay, from the lowest: compounds 1, 2 and 3 (each within the scatter of the next).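

Replacing 1,2-dimethyl-1H-imidazol-5-yl with 1H-imidazol-4-yl in this assay gives no change at the digits printed from compound 2 to compound 3 (within the scatter), although the entering group carries 1 hydrogen-bond donor and the leaving group 0. Set against the 1-methyl-1H-imidazol-2-yl group, the same read-out gives no change at the digits printed from compound 1 to compound 3 (within the scatter), so all three imidazole groups on this aromatic carbon stand level. No evidence at hand accounts for this. The compounds shown leave open whether this level holds beyond imidazoles, for instance with an amine or a carboxylic acid on this aromatic carbon.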